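The source may hold more compounds than are shown below. What is called first, only, known or untested is meant among the compounds shown, and "the series" means these compounds.

Working notes on the series.

Of the compounds shown here, three of the shared core have been measured in a functional assay on HEK293 cells for agonist activity at Toll-like receptor 8 (Homo sapiens), read by reporter gene assay; a higher number here means that more compound is needed for the effect, a lower number that less compound is needed. Compound 1 `CCCCCNc1oc2c(C)ncc(CO)c2c1Nc1ccccn1` gives 5810 nM. Compound 2 `CCCC(C)Nc1oc2c(C)ncc(CO)c2c1Nc1ccccn1` gives 9010 nM. Compound 3 `Cc1ncc(CO)c2c(Nc3ccccn3)c(NC3CCCCC3)oc12` gives 6930 nM. The steps among them are small: a 1.6-fold higher number from compound 1 to compound 2 (0.19 log units; within the scatter), a 1.2-fold higher number from compound 1 to compound 3 (0.08 log units; within the scatter) and a 1.3-fold lower number from compound 2 to compound 3 (0.11 log units; within the scatter). Compound 3 thus sits within the scatter of both other compounds, and none of the three can be set apart from the others on the numbers shown.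

Compound 4 `Cc1ncc(CO)c2c(Nc3ccccn3)c(NC(C)(C)C)oc12` is not yet measured in this assay. It differs from compound 3 as follows: tert-butyl in place of cyclohexyl on a nitrogen on an aromatic ring. Among the measured compounds shown here, the steps that bear on this change are those altering the same group on the same nitrogen, namely a 1.2-fold higher number from compound 1 to compound 3 (0.08 log units; within the scatter) and a 1.3-fold lower number from compound 2 to compound 3 (0.11 log units; within the scatter), both within the scatter, so exchanging one alkyl group for another at this place has so far not moved the readout beyond the scatter. Accordingly the expected step of a 1.0-fold higher number from compound 3 to compound 4 (0.00 log units; within the scatter) is none beyond the scatter, and compound 4 is estimated at 7000 nM, with a range from 3000 nM to 17000 nM.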

Compound 4, half-maximal effective concentration: "not active" (no number reported)
The entry for compound 4 holds no number; no gap can be computed for the estimate.
By their numbers in this assay, from the lowest: compounds 1, 3 and 2 (each within the scatter of the next).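

Among the compounds shown here, compound 4 is reported as not active without a number in this assay, so no step from compound 3 to compound 4 can be read. The compounds shown leave open whether tert-butyl in place of cyclohexyl accounts for this entry. No supporting measurement bears on this result.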